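Second chloro on the core, moved to a meta benzyl

This account rests on a few compounds, and the source may have more. Where it says the series, first, only, none or still open, it means among the compounds named here.

Compound 1 `ClCc1ccccc1Cn1cnc2c(Cl)nc(Cl)nc21` — 910 nM
Compound 2 `ClCc1cccc(Cn2cnc3ncnc(Cl)c32)c1` — > 100000 nM

The study sets compound 1 and compound 2 side by side in a functional assay on K562 cells (Homo sapiens) for cytotoxicity, read by sulforhodamine B assay, with a stated time of 48 h; a lower number here means that less compound is tolerated, a higher number that more compound is tolerated. Compound 2 sits at the assay limit, (the limit of > 100000 nM in this assay, at which 1 of the 2 values shown sits), so only a bound and no number is known for it. Compound 3 `ClCc1cccc(Cn2cnc3nc(Cl)nc(Cl)c32)c1` takes the change (chloro in place of hydrogen on an aromatic carbon). Among the compounds with values here, no step between two measured compounds shows this change, but compound 1 carries the same pair of chloro groups on the core and gives 910 nM in this assay. The author therefore expects compound 3 to tolerate clearly less compound than compound 2, with an estimated value of 3000 nM and a range from 700 nM to 30000 nM, a step of an at least 33-fold lower number from compound 2 to compound 3 (1.52 log units; beyond the scatter) that is expected to exceed the scatter.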

Compound 3, concentration lethal to 50% of the cells: 5240 nM
Compound 3: middle estimate off by 1.7-fold (0.24 log units), on the low side; the range from low to high includes it.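

In this assay, chloro in place of hydrogen on an aromatic carbon, between two ring nitrogen atoms, gives an at least 19-fold lower number from compound 2 to compound 3 (1.28 log units; beyond the scatter). This single place on the core therefore separates a compound with a measured value from one that reaches no value in this assay. Compound 2 stands at a limit, so the step is a bound and its full size stays unknown: the limit of > 100000 nM in this assay, at which 1 of the 3 values shown sits.

The compounds shown leave open whether chloro itself is needed at this place, or whether an amine or a methoxy group there would give a similar value.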